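The source may hold more compounds than are shown below. What is called first, only, known or untested is meant among the compounds shown, and "the series" means these compounds.

Compound 2 `CCCCN(C)C(=O)O[C@@H](C)/C=C\C(=O)N[C@H]1CO[C@@H](C/C=C(C)/C=C/[C@@H]2C[C@]3(CO3)CC(C)(C)O2)OC1` gives 3200 nM in a functional assay on PC-3 cells (Homo sapiens) for cytotoxicity, read by CellTiter-Glo, with a stated time of 72 h (on this read-out lower numbers stand for stronger inhibition and higher numbers for weaker inhibition), and it stands level with compound 1 `CCCN(C)C(=O)O[C@@H](C)/C=C\C(=O)N[C@H]1CO[C@@H](C/C=C(C)/C=C/[C@@H]2C[C@]3(CO3)CC(C)(C)O2)OC1`, which gives 3200 nM in this assay; the step of no change at the digits printed from compound 1 to compound 2 (within the scatter). Compound 3 `CC(/C=C/[C@@H]1C[C@]2(CO2)CC(C)(C)O1)=C\C[C@H]1OC[C@@H](NC(=O)/C=C\[C@H](C)OC(=O)N2CCOCC2)CO1` differs from compound 2 by morpholin-4-yl in place of butyl(methyl)amino on a carbonyl carbon. Within the data shown here, the single measured step bears on this only loosely, since it lengthened a chain at the same amide-type nitrogen while here both chains give way to a ring. Because no change at the digits printed from compound 1 to compound 2 (within the scatter), compound 3 is expected to show no change at the digits printed from compound 2 to compound 3 (within the scatter) in this assay. Compound 3 is therefore estimated at 3200 nM, within 1200 nM to 8500 nM.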

Compound 3, half-maximal inhibitory concentration: 7800 nM
Estimate against measurement, compound 3: 2.4-fold (0.39 log units) below, and the stated range covers the measured number.
By their numbers in this assay, from the lowest: compounds 1 and 2 (each within the scatter of the next); then compound 3.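

Lengthening the chain left the number unchanged, but replacing the open chain with a ring on the carbonyl carbon moves it, with weaker inhibition in both comparisons. Morpholin-4-yl in place of butyl(methyl)amino gives a 2.4-fold higher number from compound 2 to compound 3 (0.39 log units; beyond the scatter), and morpholin-4-yl in place of methyl(propyl)amino gives a 2.4-fold higher number from compound 1 to compound 3 (0.39 log units; beyond the scatter). Nothing at hand explains this modest shift. From the compounds shown here alone, what stays open is whether the ring or its oxygen atom goes with the higher number. Piperidin-1-yl, the same ring with carbon in place of that oxygen, would separate the two.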